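The source may hold more compounds than are shown below. What is called first, only, known or untested is meant among the compounds shown, and "the series" means these compounds.

Compound 1 `O=C1C2CCCN2C(=O)CN1CN1CCN(c2cccc3c2CC=COO3)CC1` was tested in an assay on membranes from Cerebral cortex for binding affinity to Adrenergic receptor alpha-1 (Rattus norvegicus); a lower number here means a stronger inhibitor, a higher number a weaker inhibitor. In this assay compound 1 gives only a limit, > 1000 nM, and not a number. Going by the values given here, that places compound 1 at the weak end of what has been seen so far; compound 2 `O=C1C2CCCN2C(=O)CN1CCCCN1CCN(c2cccc3ccccc23)CC1` gives 8 nM in this assay, though no step between these two is worked out here. Compound 3 `O=C1[C@@H]2CCCN2C(=O)CN1CN1CCN(c2cccc3c2CC=COO3)CC1` differs from compound 1 in one respect only: the two compounds have the same atoms and bonds; at least one stereo element is drawn with a configuration in one of them and without one in the other: 1 of 1 stereo elements differ; a stereocentre at a saturated ring carbon is drawn without a configuration in compound 1 and S in compound 3. The atoms and bonds are the same, so one of the two forms contained in compound 1 is now drawn on its own. Since compound 1 itself gives only a limit (the limit of > 1000 nM in this assay, at which 1 of the 2 values shown sits), a single form of it is not expected to turn out much stronger. The step this expectation implies is expected to be a step that the limit leaves unreadable from compound 1 to compound 3. Compound 3 is estimated at 2000 nM. The expected range for compound 3 runs from 700 nM to 6000 nM.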

Compound 3, inhibition constant: > 1000 nM
Compound 3: a limit, no number; the forecaster's own chance of this, stated with the estimate: 75%; the middle value does not contradict the limit.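

Going by these compounds alone, compound 1 and compound 3 each give only a limit in this assay, not a number, so no step between them can be read. The compounds shown leave open whether the S form drawn in compound 3 differs in strength from the two forms contained in compound 1.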